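This account rests on a few compounds, and the source may have more. Where it says the series, first, only, none or still open, it means among the compounds named here.

Compound 1, `O=C(Nc1cccc(-c2oc3cc(-c4ccc(F)cc4)ccc3c(=O)c2O)c1)c1ccc(Cl)cc1`: in a functional assay on GTL 16 cells for antiproliferative activity against GTL 16 cell line (Homo sapiens), read by CCK-8 assay, with a stated time of 72 h (on this read-out lower numbers stand for stronger inhibition and higher numbers for weaker inhibition), compound 1 gives 9140 nM.
Compound 2, `Cc1cccc(C(=O)Nc2cccc(-c3oc4cc(-c5ccc(F)cc5)ccc4c(=O)c3O)c2)c1`: in this assay compound 2 gives 10900 nM.
Compound 3, `Cc1cc(C)cc(C(=O)Nc2cccc(-c3oc4cc(-c5ccc(F)cc5)ccc4c(=O)c3O)c2)c1`: in this assay compound 3 gives 13500 nM.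

The three compounds share one core and differ only in the aryl group on the amide carbonyl. Compound 3 has the highest of the three numbers, but its neighbours lie close: a 1.2-fold higher number from compound 2 to compound 3 (0.09 log units; within the scatter), and a 1.5-fold higher number from compound 1 to compound 3 (0.17 log units; within the scatter). Neither gap is larger than the scatter of repeated measurements, so the three compounds cannot be ranked against one another on these numbers.

Compound 4, `N#Cc1ccc(C(=O)Nc2cccc(-c3oc4cc(-c5ccc(F)cc5)ccc4c(=O)c3O)c2)cc1`, has not yet been measured. It differs from compound 3 in one place: 4-cyanophenyl in place of 3,5-dimethylphenyl on a carbonyl carbon. The change swaps one aryl group on the carbonyl carbon for another, and every measured step of that kind has been small: a 1.2-fold higher number from compound 1 to compound 2 (0.08 log units; within the scatter), a 1.5-fold higher number from compound 1 to compound 3 (0.17 log units; within the scatter), and a 1.2-fold higher number from compound 2 to compound 3 (0.09 log units; within the scatter) all sit within the scatter. The closest comparison is compound 1, whose 4-chlorophenyl also carries a single substituent; in this assay compound 1 gives 9140 nM. On that basis no step beyond the scatter is expected from compound 3 to compound 4, and the estimate is a 1.4-fold lower number from compound 3 to compound 4 (0.15 log units; within the scatter). For compound 4 the expected value in this assay is 9500 nM, with a range from 4000 nM to 22000 nM.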

Compound 4, half-maximal inhibitory concentration: 31800 nM
For compound 4 the middle estimate is 3.3-fold (0.52 log units) below the measured one, and the stated range ends below it.
By their numbers in this assay, from the lowest: compounds 1, 2 and 3 (each within the scatter of the next); then compound 4.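

Among these compounds, the aryl group on the carbonyl carbon is less indifferent than the first three compounds suggested: in this assay, 4-cyanophenyl brings the first steps at this position that lie beyond the scatter, with a 2.4-fold higher number from compound 3 to compound 4 (0.37 log units; beyond the scatter) and a 2.9-fold higher number from compound 2 to compound 4 (0.47 log units; beyond the scatter) both pointing towards weaker inhibition. The cleanest comparison is the exchange of chloro for cyano on an aromatic carbon with the rest of the molecule unchanged, which gives a 3.5-fold higher number from compound 1 to compound 4 (0.54 log units; beyond the scatter) and shows that this one substituent can shift the number even though the swaps among compounds 1, 2 and 3 did not. These steps are modest, but they make compound 4 the weakest of the four compounds on this read-out, as its steps to all the others lie beyond the scatter.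

The compounds shown leave open how an aryl group carrying an amine, a carboxylic acid or a methoxy group would behave on this carbonyl carbon, and how a non-aromatic group such as cyclohexyl would behave there. No other measurement is available that bears on the result for compound 4.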